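A few compounds are considered here, and "the series" means these few. Any claim that something is new, unique, unknown or untested is made for them only; others in the source may bear on it.

In a functional assay on MDA-MB-231 cells (Homo sapiens) for antiproliferative activity, read by MTT assay, with a stated time of 72 h (on this read-out lower numbers stand for stronger inhibition and higher numbers for weaker inhibition), compound 3 `COc1ccc(Nc2ccc3c(c2)S(=O)(=O)C=C3)cc1` gives 1400 nM, which lies within the scatter of compound 1 `O=S1(=O)C=Cc2ccc(Nc3ccc(C(F)(F)F)cc3)cc21` at 1300 nM. Compound 2 `N#Cc1cccc(Nc2ccc3c(c2)S(=O)(=O)C=C3)c1` is recorded only as a limit, > 10000 nM, and that keeps the upper end of any range open. Compound 4 `O=S1(=O)C=Cc2ccc(Nc3ccc(Cl)cc3)cc21` carries chloro in place of methoxy on an aromatic carbon, (chloro in place of methoxy on an aromatic carbon). Within the data shown here, the one measured step that bears on this change is a 1.1-fold higher number from compound 1 to compound 3 (0.03 log units; within the scatter), where methoxy replaced trifluoromethyl on an aromatic carbon. In this assay no shift beyond the scatter is therefore expected. The expected step is a 1.1-fold lower number from compound 3 to compound 4 (0.03 log units; within the scatter). For compound 4 the estimated value is 1300 nM, with an expected range from 600 nM to 3000 nM.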

Compound 4, half-maximal inhibitory concentration: 6720 nM
Compound 4: middle estimate off by 5.2-fold (0.71 log units), on the low side; the whole stated range lies below it.
By their numbers in this assay, from the lowest: compounds 1 and 3 (each within the scatter of the next); then compound 4. At a limit, above all of these: compound 2.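

In this assay the record shows a 4.8-fold higher number from compound 3 to compound 4 (0.68 log units; beyond the scatter) and also a 5.2-fold higher number from compound 1 to compound 4 (0.71 log units; beyond the scatter), so chloro at this position stands apart from both methoxy and trifluoromethyl. The earlier step between those two groups lay within the scatter and gave no sign that the group at this position could shift the number at all. Nothing in the data shown accounts for this separation. As far as these compounds go, it remains open whether an amine, a carboxylic acid or a longer chain at this position would give numbers like those of compound 1 and compound 3 or like that of compound 4.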